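A few compounds are considered here, and "the series" means these few. Any claim that something is new, unique, unknown or untested is made for them only; others in the source may bear on it.

Measured compounds:
- compound 1, `COC(=O)/C=C/c1cccc(N(Cc2ccc(/C=C/c3cccc(F)c3)cc2)C(=O)C2CCCCC2)c1`; in an assay on isolated protein with Bile acid receptor (Homo sapiens) as the target (a lower number here means that less compound is needed, a higher number that more compound is needed for the effect), compound 1 gives 86 nM
- compound 2, `COC(=O)/C=C/c1cccc(N(Cc2ccc(/C=C/c3cccc(F)c3)cc2)C(=O)C(C)C)c1`; in this assay compound 2 gives 71 nM
- compound 3, `COC(=O)/C=C/c1cccc(N(Cc2ccc(-c3ccc(OC)cc3)cc2)C(=O)C2CCCCC2)c1`; in this assay compound 3 gives 89 nM

The three numbers lie close together. Between compound 1 and compound 2 the change is isopropyl in place of cyclohexyl on a carbonyl carbon, and the step is a 1.2-fold lower number from compound 1 to compound 2 (0.08 log units; within the scatter). The two cores differ by 4-methoxyphenyl in place of 2-(3-fluorophenyl)ethenyl on an aromatic carbon, with the step of a 1.0-fold higher number from compound 1 to compound 3 (0.01 log units; within the scatter). For the measured compounds named here, compound 2 and compound 3 have no step computed between them; their two values stand within the usual scatter of each other.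

Compound 4, `COC(=O)/C=C/c1cccc(N(Cc2ccc(-c3ccc(OC)cc3)cc2)C(=O)C(C)C)c1`, is not yet measured. Going by the values given here, it differs from compound 3 by isopropyl in place of cyclohexyl on a carbonyl carbon; the place is the same in both pairs, so this is the same change as the one from compound 1 to compound 2. In this assay the step from compound 3 to compound 4 is expected to be a 1.2-fold lower number from compound 3 to compound 4 (0.07 log units; within the scatter), beside the earlier one, because the same change gave a 1.2-fold lower number from compound 1 to compound 2 (0.08 log units; within the scatter) and the core of compound 3 left the number of compound 1 almost unchanged in a 1.0-fold higher number from compound 1 to compound 3 (0.01 log units; within the scatter). Compound 4 is therefore estimated at 75 nM, within 40 nM to 140 nM.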

Compound 4, half-maximal effective concentration: 97 nM
Compound 4: middle estimate off by 1.3-fold (0.11 log units), on the low side; low and high end bracket the measured number.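

In this assay, isopropyl in place of cyclohexyl on a carbonyl carbon now gives a 1.1-fold higher number from compound 3 to compound 4 (0.04 log units; within the scatter), and this step agrees with the earlier one on the other core: the same change on two cores in this assay, a 1.2-fold lower number (0.08 log units; within the scatter) from compound 1 to compound 2 and a 1.1-fold higher number (0.04 log units; within the scatter) from compound 3 to compound 4, 1.3-fold (0.12 log units) apart, within the scatter of two such steps. The aromatic change, 4-methoxyphenyl in place of 2-(3-fluorophenyl)ethenyl, reads the same way with isopropyl on the carbonyl carbon, giving a 1.4-fold higher number from compound 2 to compound 4 (0.14 log units; within the scatter), again in agreement with its earlier counterpart: the same change on two cores in this assay, a 1.0-fold higher number (0.01 log units; within the scatter) from compound 1 to compound 3 and a 1.4-fold higher number (0.14 log units; within the scatter) from compound 2 to compound 4, 1.3-fold (0.12 log units) apart, within the scatter of two such steps. For the compounds shown here, both changes therefore leave the number within the scatter on either core, but this shows only that neither change moves it here: with no step large enough to stand out, these pairs cannot show that a real effect of either change carries from one core to another.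

Still open, from the compounds shown here alone, is how the number responds to an amine or a longer chain on the carbonyl carbon, or to a carboxylic acid in place of the methyl ester. Also open, going by these compounds, is whether a change with a step beyond the scatter would carry over between these cores in the same way.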